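Three side chains, one core, and a fourth to come

This account rests on a few compounds, and the source may have more. Where it says the series, first, only, none or still open, it means among the compounds named here.

Three compounds share one core and differ only in the group on a saturated chain carbon bound to an amide-type nitrogen and a carbonyl carbon. Compound 1 `C[C@H](NC(=O)CN(c1nc(Cl)nc2[nH]cnc12)C1CC1)C(=O)OCc1ccccc1` gives 36.1% in a functional assay on the whole organism (Tail, strain ICR) with Mus musculus as the target, in the tail flick test, with a stated time of 120 min, at a dose of 25 umol/kg by the oral route; a lower number here means a weaker effect, a higher number a stronger effect of the compound at the dose given. Compound 2 `CC(C)[C@H](NC(=O)CN(c1nc(Cl)nc2[nH]cnc12)C1CC1)C(=O)OCc1ccccc1` gives 27.3% in this assay, and compound 3 `C[C@@H](O)[C@H](NC(=O)CN(c1nc(Cl)nc2[nH]cnc12)C1CC1)C(=O)OCc1ccccc1` gives 30.7% in this assay. Compound 3 thus holds the second highest of the three numbers; its nearest neighbour is reached by a number 3.4 percentage points higher from compound 2 to compound 3 (within the scatter), and its furthest by a number 5.4 percentage points lower from compound 1 to compound 3 (within the scatter). The remaining step, a number 8.8 percentage points lower from compound 1 to compound 2 (within the scatter), is likewise small. Compound 4 `O=C(CN(c1nc(Cl)nc2[nH]cnc12)C1CC1)N[C@@H](CC(=O)OCc1ccccc1)C(=O)OCc1ccccc1` carries the same core, and the change is (benzyloxycarbonyl)methyl in place of 1-hydroxyethyl on a saturated chain carbon bound to an amide-type nitrogen and a carbonyl carbon. All three measured steps touch exactly this position, and none of them moved the read-out beyond the scatter, although the group entering here is larger than any of the three already tried, and brings a second aromatic ring into the molecule. On that basis no step beyond the scatter is expected in this assay. The step from compound 3 to compound 4 is expected to be a number 1.7 percentage points lower from compound 3 to compound 4 (within the scatter). Compound 4 is therefore estimated at 29%, within a range from 17% to 41%.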

Compound 4, a percentage reported as activity, at one dose (the size of the read-out at that dose, not a potency): 12.1%
Beside the measured number, compound 4's estimate is 16.9 percentage points above it, and the stated range ends above it.
By their numbers in this assay, from the lowest: compound 4; then compounds 2, 3 and 1 (each within the scatter of the next).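

The position is not indifferent to what it carries: exchanges among methyl, isopropyl and 1-hydroxyethyl stayed within the scatter, but with (benzyloxycarbonyl)methyl in this assay there is a number 18.6 percentage points lower from compound 3 to compound 4 (beyond the scatter), a number 15.2 percentage points lower from compound 2 to compound 4 (beyond the scatter) and a number 24 percentage points lower from compound 1 to compound 4 (beyond the scatter). Among these compounds, compound 4 is thus the only compound set apart from all the others, and it has the lowest number of the four, so this side chain gives a weaker effect at the dose given. The change replaces 1-hydroxyethyl with a group that has more heavy atoms, a six-membered aromatic ring of carbon only and no hydrogen-bond donor, and nothing available here bears on which of these differences accounts for the lower number, or on any other cause.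

The compounds shown leave open whether the drop follows the aromatic ring, the added ester or the length of the side chain. A carboxylic acid, a plain benzyl group or a longer saturated chain on the same saturated chain carbon would help to separate these possibilities.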